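This account rests on a few compounds, and the source may have more. Where it says the series, first, only, none or still open, it means among the compounds named here.

Compound 1, `CC(C(=O)NCc1cccc(F)c1)N1C(=O)CCC1=O`, and compound 2, `CC(C(=O)NCc1cccc(C(F)(F)F)c1)N1C(=O)CCC1=O`, share a core and differ in one place: trifluoromethyl in place of fluoro on an aromatic carbon. Both were tested in a functional assay on the whole organism (strain Albino Swiss CD1) with Mus musculus as the target, in the maximal electroshock model; a lower number here means that less compound is needed, a higher number that more compound is needed for the effect. In this assay compound 1 gives 77.4 mg/kg, and compound 2 gives 92.4 mg/kg. The step of a 1.2-fold higher number from compound 1 to compound 2 (0.08 log units; within the scatter) is therefore small, and the two numbers cannot be told apart with confidence.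

Compound 3, `CCC(C(=O)NCc1ccc(F)cc1)N1C(=O)CCC1=O`, carries a different core; how its core differs from the core of compound 1 is not broken down here. In this assay compound 3 gives "not determined" (no result reported), so no number is available for it. Compound 4, `CCC(C(=O)NCc1ccc(C(F)(F)F)cc1)N1C(=O)CCC1=O`, is made from compound 3 by trifluoromethyl in place of fluoro on an aromatic carbon. Within the data shown here, this is the same kind of change as the one from compound 1 to compound 2, but not the same: in the earlier pair the exchanged group sits meta to a large group, whereas in compound 3 and compound 4 it sits para to a large group.

Since compound 3 has no number, the expectation for compound 4 rests on the earlier pair alone, where the exchange left the dose essentially unchanged, because compound 2 gives 92.4 mg/kg next to compound 1 at 77.4 mg/kg. Compound 4 is expected to give 90 mg/kg in this assay. The estimated range for compound 4 runs from 40 mg/kg to 200 mg/kg. This range is wide: compound 3 has no measured value to anchor it.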

Compound 4, dose for half-maximal effect: 69.4 mg/kg
Compound 4: middle estimate off by 1.3-fold (0.11 log units), on the high side; the range from low to high includes it.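

No step can be read from compound 3 to compound 4 in this assay: compound 3 carries no number there. The compounds shown leave open whether trifluoromethyl in place of fluoro, para to a large group, changes the dose as little as it does between compound 1 and compound 2. No measured evidence here bears on the value of compound 4.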